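Replacing an isopropyl with a benzyl on the disulfide

The compounds below may be only part of what the source reports. "The series", "measured", "known", "first", "only" and "open" are said of these compounds alone.

Of the compounds shown here, two have been measured in a physicochemical assay for pharmacokinetics, read by HPLC, in phosphate buffer, at pH 5; a higher number here means that the compound lasts longer, a lower number that the compound disappears faster. Compound 1 `CCSS/C(CCOC(=O)[C@@H](C)c1ccc2cc(OC)ccc2c1)=C(/C)N(C=O)CC(=O)OC[C@H]1O[C@H](O)[C@H](O)[C@@H](O)[C@@H]1O` gives 23.5 h in this assay. Compound 2 `COc1ccc2cc([C@H](C)C(=O)OCC/C(SSC(C)C)=C(\C)N(C=O)CC(=O)OC[C@H]3O[C@H](O)[C@H](O)[C@@H](O)[C@@H]3O)ccc2c1` gives 34 h in this assay. Within the data shown here, these two numbers sit within the scatter of each other, so neither compound can be said to last longer than the other; the one change between them, a 1.4-fold higher number from compound 1 to compound 2 (0.16 log units; within the scatter), left the number essentially where it was.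

Compound 3 `COc1ccc2cc([C@H](C)C(=O)OCC/C(SSCc3ccccc3)=C(\C)N(C=O)CC(=O)OC[C@H]3O[C@H](O)[C@H](O)[C@@H](O)[C@@H]3O)ccc2c1` is not yet measured. It differs from compound 2 in one place: benzyl in place of isopropyl on a sulfur. Among the measured compounds shown here, the single measured step bears on this change only loosely, since it too altered the chain carried by the disulfide, and it stayed within the scatter. For the measured compounds named here, there is no measured step that tells what a larger group on that sulfur does, so the expectation rests on the one small step seen. On that basis the step of no change at the digits printed from compound 2 to compound 3 (within the scatter) is expected to stay within the scatter. Compound 3 is therefore estimated to give 34 h in this assay, with a likely range from 17 h to 68 h.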

Compound 3, half-life: 24.1 h
The estimate for compound 3 lay 1.4-fold (0.15 log units) above the measured number; the measured number falls inside the stated range.
By their numbers in this assay, from the lowest: compounds 1, 3 and 2 (each within the scatter of the next).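

In this assay the earlier pair tested only a methyl in place of a hydrogen on the chain carbon bound to the sulfur, whereas compound 3 puts a much larger group on the sulfur: benzyl, with 7 heavy atoms and a six-membered aromatic ring of carbon only, replaces isopropyl, with 3 heavy atoms and no ring, and this gives a 1.4-fold lower number from compound 2 to compound 3 (0.15 log units; within the scatter) as the step. Set against the smaller ethyl group of compound 1, the same benzyl group gives a 1.0-fold higher number from compound 1 to compound 3 (0.01 log units; within the scatter) as the step, so all three compounds lie within the scatter of one another and this measurement cannot tell them apart, even though the group on this sulfur now spans both open chains and an aromatic ring. No separate measurement is available to explain why these groups cannot be told apart.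

All the groups shown on this sulfur are built of carbon and hydrogen alone, so it remains open whether one carrying an amine or a carboxylic acid would behave the same way. From the compounds shown here alone, a phenyl ring bound directly to the sulfur and a longer chain also remain open.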